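Ethynyl for Chloro on the Five-Membered Ring of Compound 3

This account rests on a few compounds, and the source may have more. Where it says the series, first, only, none or still open, it means among the compounds named here.

Compound 1 `C#C[C@@]1(O)[C@@H](CO)O[C@@H](n2cnc3c(-c4ccc(C)cc4)ncnc32)[C@@H]1O` and compound 2 `C#C[C@@]1(O)[C@@H](CO)O[C@@H](n2cnc3c(-c4ccc(Cl)cc4)ncnc32)[C@@H]1O` share one core; in a functional assay on CCRF-CEM cells (Homo sapiens) for antiproliferative activity, read by cell counting, with a stated time of 72 h (a higher number here means a weaker inhibitor, a lower number a stronger inhibitor), compound 1 gives 154000 nM and compound 2 gives 124000 nM. The step of a 1.2-fold lower number from compound 1 to compound 2 (0.09 log units; within the scatter) is small. Compound 3 `C#C[C@@]1(O)[C@@H](CO)O[C@@H](n2cc(Cl)c3c(N)ncnc32)[C@@H]1O` has a different core and gives 12 nM, the lowest of the three numbers, far beyond the scatter from both others. Compound 4 `C#Cc1cn([C@@H]2O[C@H](CO)[C@](O)(C#C)[C@H]2O)c2ncnc(N)c12` differs from compound 3 by ethynyl in place of chloro on an aromatic carbon. Going by the values given here, no measured step changes the five-membered ring at this position, so the step of compound 1 to compound 2 gives only a hint that small aromatic substituent swaps stay within the scatter. The expected step of a 1.3-fold higher number from compound 3 to compound 4 (0.10 log units; within the scatter) is therefore none beyond the scatter, and compound 4 is estimated at 15 nM, within 3 nM to 80 nM.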

Compound 4, half-maximal inhibitory concentration: 63000 nM
Beside the measured number, compound 4's estimate is 4200-fold (3.62 log units) below it; measured number outside the range, above it.
By their numbers in this assay, from the lowest: compound 3; then compounds 4, 2 and 1 (each within the scatter of the next, the first and the last beyond it).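

In this assay, ethynyl in place of chloro on this aromatic carbon of the five-membered ring gives a 5300-fold higher number from compound 3 to compound 4 (3.72 log units; beyond the scatter), so at this position a change of only a few heavy atoms can separate a very strong compound from a very weak one. Going by these compounds alone, the one earlier step, chloro in place of methyl, lay in another place on another core and stayed within the scatter, so it gave no sign of such sensitivity. Nothing given here explains the size of this step. Left open is how bromo, methyl or nitrile would fare at this position, and whether anything other than chloro keeps the low number of compound 3.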